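A few compounds are considered here, and "the series" means these few. Any claim that something is new, unique, unknown or untested is made for them only; others in the source may bear on it.

Measured so far in a functional assay on 143B cells (Homo sapiens) for antiproliferative activity, read by MTT assay, with a stated time of 48 h; a lower number here means a stronger inhibitor, a higher number a weaker inhibitor:
compound 1 `Cc1cccc(C(=O)Nc2cccc(/C=C/C(=O)c3nc4ccccc4[nH]3)c2)c1` — 4880 nM
compound 2 `Cc1ccc(C(=O)Nc2cccc(/C=C/C(=O)c3nc4ccccc4[nH]3)c2)cc1` — 6560 nM

Among the measured compounds shown here, compound 2 holds the higher of the two numbers in this assay, and its nearest neighbour is compound 1; the single step between them, a 1.3-fold higher number from compound 1 to compound 2 (0.13 log units; within the scatter), stays within the scatter, so the two compounds are not separated on these data.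

Compound 3 `O=C(Nc1cccc(/C=C/C(=O)c2nc3ccccc3[nH]2)c1)c1cccc(C(F)(F)F)c1` differs from compound 2 by 3-(trifluoromethyl)phenyl in place of 4-methylphenyl on a carbonyl carbon. For the measured compounds named here, the only measured step, a 1.3-fold higher number from compound 1 to compound 2 (0.13 log units; within the scatter), exchanged 3-methylphenyl for 4-methylphenyl on the same carbonyl carbon and gave no shift beyond the scatter. Going by the values given here, no measured pair replaces 4-methylphenyl with 3-(trifluoromethyl)phenyl, so the present change has no direct precedent. Among the compounds with values here, with the one known step on this carbonyl substituent flat, no shift beyond the scatter is expected for compound 3, and the estimated step is a 1.2-fold lower number from compound 2 to compound 3 (0.08 log units; within the scatter). Compound 3 is therefore estimated at 5500 nM, with a range of 1500 nM to 20000 nM reflecting the lack of a precedent for this exchange.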

Compound 3, half-maximal inhibitory concentration: 9570 nM
Estimate against measurement, compound 3: 1.7-fold (0.24 log units) below; the range from low to high includes it.
By their numbers in this assay, from the lowest: compounds 1, 2 and 3 (each within the scatter of the next).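

In this assay, this carbonyl substituent now tolerates a larger group than the methylphenyl pair had tested, with 3-(trifluoromethyl)phenyl in place of 4-methylphenyl giving no shift beyond the scatter (a 1.5-fold higher number from compound 2 to compound 3 (0.16 log units; within the scatter)). Among the compounds shown here, the comparison with the direct 3-methylphenyl analogue adds the first single exchange of trifluoromethyl for methyl on an aromatic carbon, and it also stays within the scatter (a 2.0-fold higher number from compound 1 to compound 3 (0.29 log units; within the scatter)). No accompanying measurement bears on why these numbers fall as they do.

All three aryl amides therefore remain unseparated, and no substituent on this phenyl has yet moved the number beyond the scatter. Still open, as far as these compounds go, is whether an amine or a carboxylic acid on the phenyl, or a piperazine in its place on the carbonyl carbon, would do so.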